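The source may hold more compounds than are shown below. What is called first, only, known or untested is meant among the compounds shown, and "the series" means these compounds.

In a physicochemical assay for solubility, read by spectrophotometry, in phosphate buffer, with a stated time of 18 h, at pH 7.4 (on this read-out lower numbers stand for lower solubility and higher numbers for higher solubility), three compounds have been measured:

Compound 1 `CCc1ccc(-c2nc3c(c(C)nn3-c3ccccc3)c(-c3ccccc3F)c2C#N)cc1`: 1700 nM
Compound 2 `Cc1nn(-c2ccccc2)c2nc(-c3ccc(C(C)C)cc3)c(C#N)c(-c3ccccc3O)c12`: 9800 nM
Compound 3 `CCCc1ccc(-c2nc3c(c(C)nn3-c3ccccc3)c(-c3ccccc3O)c2C#N)cc1`: 6500 nM

Compound 3 lies within the scatter of compound 2, and both numbers exceed that of compound 1. Compound 4 `Cc1nn(-c2ccccc2)c2nc(-c3ccc(I)cc3)c(C#N)c(-c3ccccc3O)c12` carries iodo in place of propyl on an aromatic carbon, para to a large group. Within the data shown here, the only measured step at that place is a 1.5-fold lower number from compound 2 to compound 3 (0.18 log units; within the scatter), propyl in place of isopropyl, and it stays within the scatter. Among the measured compounds shown here, no iodo compound has been measured, so this step offers only weak guidance. What is expected in this assay is no change beyond the scatter, an estimated 1.3-fold lower number from compound 3 to compound 4 (0.11 log units; within the scatter). For compound 4 the estimated value is 5000 nM, with an expected range of 1800 nM to 14000 nM.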

Compound 4, solubility: 1500 nM
The estimate for compound 4 lay 3.3-fold (0.52 log units) above the measured number, outside the stated range (below it).
By their numbers in this assay, from the lowest: compounds 4 and 1 (each within the scatter of the next); then compounds 3 and 2 (each within the scatter of the next).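

Among these compounds, until now the only change at this place, propyl for isopropyl, had stayed within the scatter. In this assay, going from 4-propylphenyl to 4-iodophenyl gives a 4.3-fold lower number from compound 3 to compound 4 (0.64 log units; beyond the scatter) and iodo in place of isopropyl gives a 6.5-fold lower number from compound 2 to compound 4 (0.82 log units; beyond the scatter), so the number at this aromatic carbon does depend on the group it carries. No evidence at hand accounts for this drop. Going by these compounds, whether it is particular to iodo stays open: a chloro, an amine or a carboxylic acid at the same place could fall with it or stay with the alkyl compounds.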